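Aryl in place of tert-butyl: what to expect of compound 4

The compounds below may be only part of what the source reports. "The series", "measured", "known", "first", "only" and "open" are said of these compounds alone.

Compound 1 `CC(C)n1nc(-c2cc(C(C)(C)C)on2)c2c(N)ncnc21` in an assay on TT cells for inhibition of proto-oncogene tyrosine-protein kinase receptor Ret variant C634W (Homo sapiens), read by MTT assay, with a stated time of 10 days (a higher number here means a weaker inhibitor of growth, a lower number a stronger inhibitor of growth), gives > 10000 nM, a limit of the assay and not a number.
Compound 2 `Nc1ncnc2c1c(-c1cc(C3CC3)on1)nn2C1CCCCC1` in this assay gives 290 nM.
Compound 3 `CC(C)n1nc(/C=N/O)c2c(N)ncnc21` in this assay gives > 10000 nM, again only a limit.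

Compound 1 thus stands at the limit of > 10000 nM in this assay, at which 2 of the 3 values shown sit, without a number of its own, and only compound 2 yields a measured value. Compound 4 `CC(C)n1nc(-c2cc(-c3ccc(F)cc3)on2)c2c(N)ncnc21` differs from compound 1 by 4-fluorophenyl in place of tert-butyl on an aromatic carbon. Within the data shown here, no measured pair shows this change, so its size is open. With compound 1 at a limit, any number for compound 4 would mean stronger inhibition. The step is expected to be an at least 3.3-fold lower number from compound 1 to compound 4 (0.52 log units; beyond the scatter). For compound 4 the expected value in this assay is 3000 nM, between 300 nM and 20000 nM, with a real chance that only a limit is reported again.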

Compound 4, concentration for 50% growth inhibition: > 10000 nM
Compound 4 was reported as a limit; the forecaster's own chance of this, stated with the estimate: 40%; at least 3.3-fold (0.52 log units) between middle value and limit.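

Among these compounds, compound 1 and compound 4 are both reported only as limits in this assay, and no step between them can be read. The compounds shown leave open how 4-fluorophenyl in place of tert-butyl changes growth inhibition, if it changes it at all.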